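Series notes: benzyl for cyclohexyl on the imidazole nitrogen

This account rests on a few compounds, and the source may have more. Where it says the series, first, only, none or still open, it means among the compounds named here.

Measured compounds:
compound 1 `c1cn2cc(-c3ccsc3)nc(-c3ccc4ncn(C5CCCCC5)c4c3)c2n1` 15.4%
compound 2 `Brc1ccc(-c2cn3ccnc3c(-c3ccc4ncn(C5CCCCC5)c4c3)n2)cc1` 23.3%
compound 3 `c1cn2cc(-c3ccc4c(c3)ncn4C3CCCCC3)nc(-c3ccc4ncn(C5CCCCC5)c4c3)c2n1` 30.6%

In a functional assay on KM12 cells (Homo sapiens) for inhibition, read by sulforhodamine B assay, with a stated time of 48 h, tested at 10 uM (a higher number here means more inhibition at the concentration tested (going by the name of the read-out), a lower number less inhibition), compound 3 gives the highest of the three numbers; the gap to compound 2 is within the usual scatter, while the gap to compound 1 is beyond it, so compound 3 is separated only from compound 1. For the measured compounds named here, the one step between measured compounds is a number 7.9 percentage points higher from compound 1 to compound 2 (within the scatter); it concerns the aryl group on the core and not the substituent on the ring nitrogen.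

Compound 4 `c1ccc(Cn2cnc3ccc(-c4nc(-c5ccc6c(c5)ncn6C5CCCCC5)cn5ccnc45)cc32)cc1` is not yet measured. It differs from compound 3 by benzyl in place of cyclohexyl on an aromatic nitrogen. Going by the values given here, no measured step bears on this change; the substituent on that nitrogen is the same in all three measured compounds. Without a precedent, the expected step is a number 0.6 percentage points lower from compound 3 to compound 4 (within the scatter), none beyond the scatter, and compound 4 is estimated at 30% with a range from 15% to 45%.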

Compound 4, a percentage reported as inhibition, at one concentration (the size of the read-out at that concentration, not a potency): -39.4%
Compound 4: middle estimate off by 69.4 percentage points, on the high side; measured number below the stated range.
By their numbers in this assay, from the lowest: compound 4; then compounds 1, 2 and 3 (each within the scatter of the next, the first and the last beyond it).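

In this assay, for the compounds shown here, the substituent on the aromatic nitrogen proves to be a sensitive place: a number 70 percentage points lower from compound 3 to compound 4 (beyond the scatter), whereas the only earlier step, on the aryl group of the core, was a number 7.9 percentage points higher from compound 1 to compound 2 (within the scatter). Compound 4 gives -39.4%, so the change does not merely lessen the inhibition seen with compound 3 but takes the reading below zero. Cyclohexyl and benzyl are both six-membered carbon rings with no hydrogen-bond donors, acceptors or net charge, and nothing available accounts for the step.

On these data alone, compound 3 carries two cyclohexyl groups and only one is replaced here, so whether the other behaves the same way remains open. Also open, as far as these compounds go, is whether the step belongs to benzyl specifically: phenyl, methyl or a longer chain ending in an amine on that nitrogen would test this.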